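From a bromophenyl to a methylphenyl on the shared core

This account rests on a few compounds, and the source may have more. Where it says the series, first, only, none or still open, it means among the compounds named here.

Compound 3 `CC(C)=CCOc1cc(O)c2c(c1)OC(c1ccccc1Br)CC2=O` gives 3820 nM in a functional assay; on this read-out lower numbers stand for stronger inhibition and higher numbers for weaker inhibition. Compound 1 `CC(C)=CCOc1cc(O)c2c(c1)OC(c1ccc(F)cc1)CC2=O` gives 6060 nM, and compound 2 `CC(C)=CCOc1cc(O)c2c(c1)OC(c1ccc(Cl)cc1)CC2=O` gives 7020 nM. The steps of a 1.6-fold lower number from compound 1 to compound 3 (0.20 log units; within the scatter) and a 1.8-fold lower number from compound 2 to compound 3 (0.26 log units; within the scatter) both lie within the scatter, so the three compounds cannot be told apart on this read-out, and no one of them can be called the most potent.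

Compound 4 `CC(C)=CCOc1cc(O)c2c(c1)OC(c1ccc(C)cc1)CC2=O` has not yet been measured. It differs from compound 3 in one place. 4-methylphenyl in place of 2-bromophenyl on a saturated ring carbon

The measured steps that bear on this change are a 1.2-fold higher number from compound 1 to compound 2 (0.06 log units; within the scatter), a 1.6-fold lower number from compound 1 to compound 3 (0.20 log units; within the scatter) and a 1.8-fold lower number from compound 2 to compound 3 (0.26 log units; within the scatter). None of them went beyond the scatter, whether the halogen on the phenyl was exchanged or the whole phenyl group was replaced. For the measured compounds named here, no measured compound carries a methyl on this phenyl, so the data give no direct guide to it. For compound 4 the expected step is therefore a 1.3-fold higher number from compound 3 to compound 4 (0.12 log units; within the scatter), a change not beyond the scatter. Compound 4 is estimated at 5000 nM, with a range from 2500 nM to 10000 nM.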

Compound 4, half-maximal inhibitory concentration: 4360 nM
The estimate for compound 4 lay 1.1-fold (0.06 log units) above the measured number, and the stated range covers the measured number.
By their numbers in this assay, from the lowest: compounds 3, 4, 1 and 2 (each within the scatter of the next).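

In this assay, a methyl on the phenyl group proves no more distinguishable than the halogens: a 1.1-fold higher number from compound 3 to compound 4 (0.06 log units; within the scatter), a 1.6-fold lower number from compound 2 to compound 4 (0.21 log units; within the scatter) and a 1.4-fold lower number from compound 1 to compound 4 (0.14 log units; within the scatter) all stay within the scatter. On the saturated ring carbon next to the ring oxygen, 4-methylphenyl therefore reads the same as 2-bromophenyl, and across these four compounds no exchange on the phenyl group separates one compound from another. No evidence is available to explain why these numbers lie so close together.

The compounds shown leave open whether an amine or a carboxylic acid on the phenyl group would move the number beyond the scatter. They also leave open whether 2-methylphenyl would read like 4-methylphenyl, since the step from compound 3 changes both the group and its place on the ring.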